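The compounds below may be only part of what the source reports. "The series", "measured", "known", "first", "only" and "open" are said of these compounds alone.

Measured so far in an ADME assay on PANC-1 cells (Homo sapiens) for cytotoxicity, read by MTT assay; on this read-out lower numbers stand for higher toxicity in this test and higher numbers for lower toxicity in this test:
compound 1 `Cc1nc(-c2cccnc2)sc1-c1nnc(-c2ccc(Cl)cc2)o1`: > 100 ug/mL
compound 2 `Cc1ccc(-c2nnc(-c3sc(-c4cccnc4)nc3C)o2)cc1`: > 100 ug/mL
compound 3 `Cc1ccccc1-c1nnc(-c2sc(-c3cccnc3)nc2C)o1`: > 100 ug/mL

All three entries are limits, not numbers: the limit of > 100 ug/mL in this assay, at which 3 of the 3 values shown sit. Compound 1 therefore stands only at its limit of > 100 ug/mL in this series.

Compound 4 `Cc1nc(-c2cccnc2)sc1-c1nnc(-c2cccnc2)o1` carries pyridin-3-yl in place of 4-chlorophenyl on an aromatic carbon.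

Among the measured compounds shown here, three measured steps bear on this change: a step that the two limits leave unreadable from compound 1 to compound 2, a step that the two limits leave unreadable from compound 1 to compound 3 and a step that the two limits leave unreadable from compound 2 to compound 3. Each alters the same group, and none has a readable size. For the measured compounds named here, no step of readable size or direction is therefore expected in this assay, and the estimated step is a step that the limit leaves unreadable from compound 1 to compound 4 as a working figure only. A report as a limit is the likeliest outcome. For compound 4 the expected value is 150 ug/mL, with an estimated range from 70 ug/mL to 300 ug/mL.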

Compound 4, half-maximal cytotoxic concentration: > 100 ug/mL
Compound 4: only a limit was reported (the forecaster's own chance of this, stated with the estimate: 85%); the middle value lies beyond the limit too.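

Compound 4 joins compound 1, compound 2 and compound 3 as a limit, so no step between them can be read: the limit of > 100 ug/mL in this assay, at which 4 of the 4 values shown sit.

As far as these compounds go, whether these compounds differ at all in this assay remains open.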